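The source may hold more compounds than are shown below. What is called first, only, known or untested is meant among the compounds shown, and "the series" means these compounds.

Of the compounds shown here, two of one series have been tested in a functional assay on MCF7 cells (Homo sapiens) for cytotoxicity, with a stated time of 72 h; on this read-out lower numbers stand for stronger inhibition and higher numbers for weaker inhibition. Compound 1 `CC(C)[C@H](NC(=O)c1ccc(Cl)cc1O)C(=O)Nc1ccc(Cl)c(Cl)c1` gives > 10000 nM, which is a limit of the assay rather than a number. Compound 2 `O=C(CNC(=O)c1cc(Cl)ccc1O)Nc1cccc(Cl)c1` likewise gives > 10000 nM in this assay, again a limit rather than a number. Compound 2 thus stands at the limit of > 10000 nM in this assay, at which 2 of the 2 values shown sit; among the values shown there is no number at all, only these two limits, and nothing about order between compound 1 and compound 2 can be read from them. Compound 3 `C[C@H](NC(=O)c1cc(Cl)ccc1O)C(=O)Nc1cccc(Cl)c1` has not yet been measured. It differs from compound 2 in one place: methyl in place of hydrogen on a saturated chain carbon bound to an amide-type nitrogen and a carbonyl carbon. Going by the values given here, no step between measured compounds is available to guide the expectation, so the size of the step is judged from the starting point alone. Compound 2 sits at a limit in this assay. The step is accordingly expected to stay within the scatter, in no clear direction, and the estimate means a step that the limit leaves unreadable from compound 2 to compound 3. Compound 3 is therefore expected to give 15000 nM in this assay, with a range from 5000 nM to 50000 nM, most likely again as a limit rather than a number.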

Compound 3, half-maximal inhibitory concentration: > 10000 nM
Compound 3: no number, only a limit; the forecaster's own chance of this, stated with the estimate: 80%; the middle value does not contradict the limit.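

Going by these compounds alone, compound 2 and compound 3 both sit at a limit rather than a number, and no step between them can be read. The compounds shown leave open whether methyl in place of hydrogen at this place alters the read-out in this assay, and how any of the three compounds rank, as all share one limit: the limit of > 10000 nM in this assay, at which 3 of the 3 values shown sit.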